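Chlorophenyl Isomer of a Series Held at the Limit

The source may report more compounds than this note shows. Statements on the series, on what has been measured and on what is new or still open speak of the compounds shown alone.

Compound 1, `COc1nc2c(c(=O)n(C)c(=O)n2C)n1CC(=O)Nc1cccc(Cl)c1`, in an assay on isolated protein for inhibition of high affinity 3',5'-cyclic-AMP phosphodiesterase 7A (Homo sapiens), read by cAMP accumulation, with a stated time of 10 min; on this read-out lower numbers stand for stronger inhibition and higher numbers for weaker inhibition: > 200000 nM, a limit of the assay.
Compound 2, `COc1nc2c(c(=O)n(C)c(=O)n2C)n1CC(=O)Nc1ccc(C(C)C)cc1`, in this assay: > 200000 nM, again a limit.
Compound 3, `COc1nc2c(c(=O)n(C)c(=O)n2C)n1CCCC(=O)Nc1cccc(Cl)c1`, in this assay: > 200000 nM, also a limit.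

Compound 3 thus stands only at a limit in this assay, as do the two others shown. Compound 4, `COc1nc2c(c(=O)n(C)c(=O)n2C)n1CCCC(=O)Nc1ccc(Cl)cc1`, differs from it by 4-chlorophenyl in place of 3-chlorophenyl on an amide-type nitrogen. Among the compounds with values here, no measured step bears directly on this change; the single measured step, a step that the two limits leave unreadable from compound 1 to compound 2, is unreadable with both of its compounds at the limit. What the numbers offer is the limit of > 200000 nM in this assay, at which 3 of the 3 values shown sit. The step from compound 3 to compound 4 is expected to be a step that the limit leaves unreadable from compound 3 to compound 4, not readable beyond the limit. Compound 4 is therefore expected to remain at the limit, estimated at 300000 nM within 100000 nM to 1000000 nM.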

Compound 4, half-maximal inhibitory concentration: > 200000 nM
Compound 4: a limit, no number; the forecaster's own chance of this, stated with the estimate: 85%; the middle value does not contradict the limit.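

Compound 3 and compound 4 both stand only at a limit in this assay, and the step between them cannot be read. The compounds shown leave open whether 3-chlorophenyl and 4-chlorophenyl differ at all, and what would give a readable number.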